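The source may report more compounds than this note shows. Statements on the series, on what has been measured and on what is new or still open speak of the compounds shown alone.

Measured compounds in a functional assay on HeLa cells (Homo sapiens) for cytotoxicity, read by MTT assay, with a stated time of 72 h; a higher number here means a weaker inhibitor, a lower number a stronger inhibitor:
- compound 1 `O=C1c2cccc([N+](=O)[O-])c2NC[C@@]12[C@H](c1ccc(F)cc1)[C@@H](c1ccccc1)N[C@]21C(=O)Nc2ccc(Cl)cc21`: 27000 nM
- compound 2 `O=C1c2cccc([N+](=O)[O-])c2NC[C@@]12[C@H](c1ccc(Cl)cc1)[C@@H](c1ccccc1)N[C@]21C(=O)Nc2ccc(Br)cc21`: 23000 nM
- compound 3 `O=C1c2cccc([N+](=O)[O-])c2NC[C@@]12[C@H](c1ccc(Cl)cc1)[C@@H](c1ccccc1)N[C@]21C(=O)Nc2ccc(F)cc21`: 25000 nM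

Compound 3 stands second highest of the three numbers. Its nearest neighbour is compound 1, whose value lies within the scatter of that of compound 3; the furthest is compound 2, also within the scatter. In effect the three measured compounds are indistinguishable in this assay.

Compound 4 `O=C1c2cccc([N+](=O)[O-])c2NC[C@@]12[C@H](c1ccc(F)cc1)[C@@H](c1ccccc1)N[C@]21C(=O)Nc2ccc(F)cc21` has not yet been measured. It differs from compound 3 by fluoro in place of chloro on an aromatic carbon. For the measured compounds named here, the one measured step of the same kind, a halogen swap on an aromatic carbon, is a 1.1-fold higher number from compound 2 to compound 3 (0.04 log units; within the scatter). Compound 1, which also carries the 4-fluorophenyl found in compound 4, gives a value within the scatter of compound 3. Going by the values given here, no measured step in this set moves beyond the scatter, so the halogen exchange from compound 3 to compound 4 is expected to produce no step beyond the scatter in this assay, which would be no change at the digits printed from compound 3 to compound 4 (within the scatter).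

Compound 4 is therefore estimated at 25000 nM in this assay, with a range from 14000 nM to 45000 nM.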

Compound 4, half-maximal inhibitory concentration: 20000 nM
The estimate for compound 4 lay 1.3-fold (0.10 log units) above the measured number, and the stated range covers the measured number.
By their numbers in this assay, from the lowest: compounds 4, 2, 3 and 1 (each within the scatter of the next).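

In this assay, the change from 4-chlorophenyl to 4-fluorophenyl gives a 1.3-fold lower number from compound 3 to compound 4 (0.10 log units; within the scatter), so this position now has a direct comparison of these two halogens, and the exchange does not move the value beyond the scatter. The same chloro-to-fluoro exchange on the other halogen-bearing aromatic ring gives a 1.4-fold lower number from compound 1 to compound 4 (0.13 log units; within the scatter), also within the scatter, so compound 4, with fluoro in both places, shows that neither single exchange separates it from its chloro-bearing partner. No accompanying measurement bears on why these halogen exchanges leave the cytotoxicity read-out within the scatter.

All the compounds shown keep a halogen in both places, so it remains open whether the value depends on having a halogen there at all, or whether a hydrogen, a methoxy group, an amine or a carboxylic acid on the same aromatic carbon would give a step beyond the scatter. The nitro group and the unsubstituted phenyl are also common to all of these compounds, so their replacement, for example of the nitro group by an amine, remains an open question in this assay.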